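Taking the Benzyl Group Off Compound 2

The compounds below may be only part of what the source reports. "The series", "measured", "known", "first", "only" and "open" are said of these compounds alone.

Going by the values given here, in a functional assay on CCRF-CEM cells (Homo sapiens) for cytotoxicity, in the absence of a further agent (on this read-out lower numbers stand for stronger inhibition and higher numbers for weaker inhibition), compound 2 `COC(=O)c1ccc(CN(CCCc2c(N)nc(N)nc2O)c2cc(F)c([N+](=O)[O-])cc2[N+](=O)[O-])cc1` gives 4300 nM, the only actual number so far. Compound 3 `Nc1nc(N)c(CCCNc2cc(F)c([N+](=O)[O-])cc2[N+](=O)[O-])c(O)n1` differs from it by one change: hydrogen in place of 4-(methoxycarbonyl)benzyl on a nitrogen on an aromatic ring. Compound 1 `Nc1nc(N)c(CCCNc2cc(F)ccc2[N+](=O)[O-])c(O)n1`, which also has hydrogen on such a nitrogen, is reported at > 100000 nM, a limit of the assay and not a number. On that basis, a sizeable loss of inhibition is expected in this assay. The expected change is a 5.8-fold higher number from compound 2 to compound 3 (0.76 log units; beyond the scatter), towards weaker inhibition. For compound 3 the estimated value is 25000 nM, with an expected range of 6000 nM to 100000 nM.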

Compound 3, half-maximal inhibitory concentration: 1000 nM
The estimate for compound 3 lay 25-fold (1.40 log units) above the measured number; measured number outside the range, below it.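

In this assay, hydrogen on this nitrogen on an aromatic ring gives stronger inhibition than 4-(methoxycarbonyl)benzyl, with a 4.3-fold lower number from compound 2 to compound 3 (0.63 log units; beyond the scatter), so the benzyl group is not required for inhibition here. Hydrogen on that nitrogen does not by itself mean weak inhibition: with it kept, nitro in place of hydrogen on an aromatic carbon gives an at least 100-fold lower number from compound 1 to compound 3 (2.00 log units; beyond the scatter). That step rests on a limit for compound 1, not a number: the limit of > 100000 nM in this assay, at which 1 of the 3 values shown sits.

Open, as far as these compounds go, is whether a methyl or an unsubstituted benzyl on this nitrogen would keep the gain. Also open, from the compounds shown here alone, is whether a carboxylic acid in place of the methyl ester would change the number of compound 2.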